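This account rests on a few compounds, and the source may have more. Where it says the series, first, only, none or still open, it means among the compounds named here.

Measured so far:
compound 1, `CC(C)(C)OC(=O)N1CC=C(c2nc(COc3ccc(-n4cnnn4)cc3Cl)cs2)CC1`, 107 nM;
compound 2, `CCc1cnc(N2CC=C(c3nc(COc4ccc(-n5cnnn5)cc4F)cs3)CC2)nc1`, 8.8 nM.

Both numbers come from a functional assay on isolated protein for agonist activity at Glucose-dependent insulinotropic receptor (Homo sapiens), read by HTRF and cAMP accumulation; on this read-out lower numbers stand for an effect already at smaller amounts and higher numbers for an effect only at larger amounts of compound. Of the two, compound 2 stands at the lower number, and compound 1 sits well apart from it, beyond the scatter of repeated measurements. The two compounds differ from one another in more than one place, so their values say nothing about any single change on its own.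

Compound 3, `CCc1cnc(N2CC=C(c3nc(COc4ccc(-n5cnnn5)cc4Cl)cs3)CC2)nc1`, has not yet been measured in this assay. Compared with compound 2 it carries one change, (chloro in place of fluoro on an aromatic carbon), on an aromatic carbon of a six-membered aromatic ring of carbon only, ortho to a large group and meta to a 1H-tetrazol-1-yl group. Among the compounds with values here, no pair of measured compounds isolates this swap, so there is nothing in hand to size it from. The exchange of one halogen for another at the same place is expected to shift the number little, most likely within the scatter, with no clear direction. For compound 3 in this assay the estimate is 10 nM, between 4 nM and 30 nM, meaning a step of a 1.1-fold higher number from compound 2 to compound 3 (0.06 log units; within the scatter).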

Compound 3, half-maximal effective concentration: 10.2 nM
Compound 3: middle estimate off by 1.0-fold (0.01 log units), on the low side; measured number inside the range.
By their numbers in this assay, from the lowest: compounds 2 and 3 (each within the scatter of the next); then compound 1.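

In this assay, chloro in place of fluoro on an aromatic carbon, ortho to a large group and meta to a 1H-tetrazol-1-yl group, gives a 1.2-fold higher number from compound 2 to compound 3 (0.06 log units; within the scatter), so with 5-ethylpyrimidin-2-yl on the ring nitrogen, the two halogens cannot be told apart at this position. The same measurement also isolates the group on the amine nitrogen, which the earlier pair, differing in more than one place, could not do: with chloro held constant, 5-ethylpyrimidin-2-yl in place of tert-butoxycarbonyl gives a 10-fold lower number from compound 1 to compound 3 (1.02 log units; beyond the scatter), a large step that sets this nitrogen substituent apart from the silent halogen swap. Nothing in hand gives a reason for either step.

From the compounds shown here alone, the halogen result rests on one pair carrying one nitrogen substituent, so it remains open whether fluoro and chloro would also match each other with tert-butoxycarbonyl on that nitrogen. Also open, going by these compounds, is what hydrogen, methyl, methoxy or a nitrile would give on the same aromatic carbon, and how a simple amide or a longer alkyl chain on the pyrimidine would compare with the 5-ethylpyrimidin-2-yl group.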